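Swapping Acetyl for Methoxy on the Amide-Bearing Ring

A few compounds are considered here, and "the series" means these few. Any claim that something is new, unique, unknown or untested is made for them only; others in the source may bear on it.

Of the compounds shown here, three built on one shared core have been tested in a functional assay on L1210 cells (Mus musculus) for cytotoxicity; on this read-out lower numbers stand for stronger inhibition and higher numbers for weaker inhibition. Compound 1 `O=C(/C=C/C(=O)N1C/C(=C\c2ccccc2)C(=O)/C(=C/c2ccccc2)C1)Nc1ccc([N+](=O)[O-])cc1` gives 40000 nM. Compound 2 `CC(=O)c1ccc(NC(=O)/C=C/C(=O)N2C/C(=C\c3ccccc3)C(=O)/C(=C/c3ccccc3)C2)cc1` gives 5500 nM, and compound 3 `Cc1ccc(NC(=O)/C=C/C(=O)N2C/C(=C\c3ccc([N+](=O)[O-])cc3)C(=O)/C(=C/c3ccc([N+](=O)[O-])cc3)C2)cc1C` gives 4900 nM. Within the data shown here, compound 2 thus stands between the other two numbers: the only single-point step measured so far, a 7.3-fold lower number from compound 1 to compound 2 (0.86 log units; beyond the scatter), separates it from compound 1, while its gap to compound 3 lies within the usual scatter of this assay, so those two cannot be ranked against each other.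

Compound 4 `COc1ccc(NC(=O)/C=C/C(=O)N2C/C(=C\c3ccccc3)C(=O)/C(=C/c3ccccc3)C2)cc1` has not yet been measured. It differs from compound 2 in one place: methoxy in place of acetyl on an aromatic carbon. Among the measured compounds shown here, no measured pair shows this particular exchange. For the measured compounds named here, the one step that bears on it, a 7.3-fold lower number from compound 1 to compound 2 (0.86 log units; beyond the scatter), shows that changing the group at this place can shift the number by a modest amount. Going by the values given here, with that as the only guide, a step of about the same size or smaller is expected for compound 4, with its direction uncertain. On balance compound 4 is estimated at 8000 nM, within a range from 2500 nM to 25000 nM, which corresponds to an expected step of a 1.5-fold higher number from compound 2 to compound 4 (0.16 log units; within the scatter).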

Compound 4, half-maximal inhibitory concentration: 6800 nM
Compound 4: middle estimate off by 1.2-fold (0.07 log units), on the high side; the range from low to high includes it.
By their numbers in this assay, from the lowest: compounds 3, 2 and 4 (each within the scatter of the next); then compound 1.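

In this assay, exchanging acetyl for methoxy on the aromatic ring that carries the amide gives a 1.2-fold higher number from compound 2 to compound 4 (0.09 log units; within the scatter), so the two groups cannot be told apart at this place. Nitro at the same place does stand apart from both: alongside a 7.3-fold lower number from compound 1 to compound 2 (0.86 log units; beyond the scatter) there is now a 5.9-fold lower number from compound 1 to compound 4 (0.77 log units; beyond the scatter), which makes two separate steps beyond the scatter that point the same way. Among these three groups, then, only nitro goes with a distinct number, and no accompanying measurement says what lies behind that difference.

The compounds shown leave open how other kinds of group would behave at this place, such as an amine, a carboxylic acid or a longer chain like ethoxy, and whether any of them would fall with acetyl and methoxy or with nitro. They also leave open whether acetyl and methoxy would still match once the other aromatic rings of the shared core are changed, as they are in compound 3, which differs from these compounds in more than one place.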